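Replacing a Methyl with a Dimethylpiperidine Group

The source may hold more compounds than are shown below. What is called first, only, known or untested is meant among the compounds shown, and "the series" means these compounds.

Compound 1 `CC1=NN(C(=O)/C=C/c2ccccc2)C(c2ccccc2O)C1` gives 42000 nM in a functional assay on PC-3 cells (Homo sapiens) for cytotoxicity, read by MTT assay, with a stated time of 48 h; on this read-out lower numbers stand for stronger inhibition and higher numbers for weaker inhibition.
Compound 2 `CC(=O)Oc1ccccc1C1CC(C)=NN1C(=O)CN1CCC(C(C)=O)CC1` gives 6800 nM in this assay.
Compound 3 `CCC(=O)N1N=C(c2cc3ccccc3oc2=O)CC1c1ccccc1` gives 4370 nM in this assay.

Compound 3 carries the lowest of the three numbers. Its gap to compound 2 lies within the scatter, so no order between those two can be read, while its gap to compound 1 lies beyond the scatter. Compound 4 `CC1CC(C)CN(CC(=O)N2N=C(c3cc4ccccc4oc3=O)CC2c2ccccc2)C1` has not yet been tested in this assay. It differs from compound 3 in one place: 3,5-dimethylpiperidin-1-yl in place of methyl on a saturated chain carbon bound to a carbonyl carbon. Going by the values given here, no measured pair shows this change directly. Compound 2 also bears a piperidin-1-yl ring on a chain bound to a carbonyl and gives 6800 nM, close to the number of compound 3. On that basis the expected step of a 1.1-fold lower number from compound 3 to compound 4 (0.04 log units; within the scatter) is none beyond the scatter. Compound 4 is therefore estimated at 4000 nM, within a range from 1500 nM to 12000 nM.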

Compound 4, half-maximal inhibitory concentration: "not active" (no number reported)
The entry for compound 4 holds no number, so the estimate cannot be set against anything.
By their numbers in this assay, from the lowest: compounds 3 and 2 (each within the scatter of the next); then compound 1.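

Going by these compounds alone, compound 4 is reported as not active in this assay with no number, so no step from compound 3 to compound 4 can be read. How far its activity lies from compound 3 stays open, and no measurement shown explains the result.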